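From an Amine-Bearing Chain to a Chloropyridine Amide

The compounds below may be only part of what the source reports. "The series", "measured", "known", "first", "only" and "open" are said of these compounds alone.

The compounds share one core carrying an amide, and they differ only in the group on the carbonyl carbon of that amide. Compound 1 `C=CC(=O)Nc1cccc(-c2nc3ccccc3s2)c1` bears a vinyl group there; in an ADME assay on HEK293 cells (Homo sapiens) for inhibition, with a stated time of 72 h (a higher number here means that more compound is needed for the effect, a lower number that less compound is needed), compound 1 gives only a limit, > 25000 nM. Compound 2 `O=C(O)/C=C/C(=O)Nc1cccc(-c2nc3ccccc3s2)c1` bears 2-carboxyethenyl; in this assay compound 2 also gives only a limit, > 25000 nM. Compound 3 `CN(C)CCC(=O)Nc1cccc(-c2nc3ccccc3s2)c1` bears 2-(dimethylamino)ethyl; in this assay compound 3 likewise gives only a limit, > 25000 nM. The steps among them, a step that the two limits leave unreadable from compound 1 to compound 2, a step that the two limits leave unreadable from compound 1 to compound 3 and a step that the two limits leave unreadable from compound 2 to compound 3, cannot be read because of the limit of > 25000 nM in this assay, at which 3 of the 3 values shown sit. Compound 4 `O=C(Nc1cccc(-c2nc3ccccc3s2)c1)c1ccnc(Cl)c1` differs from compound 3 in one place: 2-chloropyridin-4-yl in place of 2-(dimethylamino)ethyl on a carbonyl carbon. For the measured compounds named here, none of the measured steps yields a readable size or direction that bears on this exchange. Because (the limit of > 25000 nM in this assay, at which 3 of the 3 values shown sit), compound 4 is expected to remain at that limit, which corresponds to an estimated step that the limit leaves unreadable from compound 3 to compound 4. For compound 4 in this assay the estimate is 30000 nM, with a range from 10000 nM to 100000 nM.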

Compound 4, half-maximal effective concentration: > 25000 nM
Compound 4 ended at the assay's limit; the forecaster's own chance of this, stated with the estimate: 85%; the middle value lies beyond the limit too.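

For the compounds shown here, compound 4 gives only a limit in this assay, so no step from compound 1, compound 2 or compound 3 to compound 4 can be read: the limit of > 25000 nM in this assay, at which 4 of the 4 values shown sit. The compounds shown leave open whether any group on the carbonyl carbon changes the half-maximal effective concentration in this assay.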